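This account rests on a few compounds, and the source may have more. Where it says the series, first, only, none or still open, it means among the compounds named here.

Compound 1 `COc1ccc(/C=C/C(=O)/C=C/C2=C(C)CCCC2(C)C)cc1` and compound 3 `COc1ccccc1/C=C/C(=O)/C=C/C1=C(C)CCCC1(C)C` share the same atoms joined differently; the difference between the two cores is not broken down here. In a functional assay on MCF7 cells (Homo sapiens) for cytotoxicity, read by sulforhodamine B assay, with a stated time of 48 h (on this read-out higher numbers stand for weaker inhibition and lower numbers for stronger inhibition), compound 1 gives 19600 nM and compound 3 gives 13400 nM, a gap within the scatter. Compound 2 `CC1=C(/C=C/C(=O)/C=C/c2ccc([N+](=O)[O-])cc2)C(C)(C)CCC1` carries the change nitro in place of methoxy on an aromatic carbon and in this assay gives 5500 nM; the step of a 3.6-fold lower number from compound 1 to compound 2 (0.55 log units; beyond the scatter). Compound 4 `CC1=C(/C=C/C(=O)/C=C/c2ccccc2[N+](=O)[O-])C(C)(C)CCC1` carries the change (nitro in place of methoxy on an aromatic carbon), the same kind of change, though here the place is ortho to a large group rather than para to it. A step of similar direction is expected from compound 3 to compound 4, about a 3.0-fold lower number from compound 3 to compound 4 (0.47 log units; beyond the scatter), resting on the step of a 3.6-fold lower number from compound 1 to compound 2 (0.55 log units; beyond the scatter). For compound 4 the expected value in this assay is 4500 nM, with a range from 2000 nM to 12000 nM.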

Compound 4, half-maximal inhibitory concentration: 10100 nM
Estimate against measurement, compound 4: 2.2-fold (0.35 log units) below; measured number inside the range.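

In this assay, nitro in place of methoxy on an aromatic carbon gives a 1.3-fold lower number from compound 3 to compound 4 (0.12 log units; within the scatter), so this pair shows no separable change. The step therefore does not carry over at the same size from one core to the other: the same change on two cores in this assay, a 3.6-fold lower number (0.55 log units; beyond the scatter) from compound 1 to compound 2 and a 1.3-fold lower number (0.12 log units; within the scatter) from compound 3 to compound 4, 2.7-fold (0.43 log units) apart, beyond the scatter of two such steps

Two pairs show only that the size of the step is not transferable between these cores; they do not explain the difference or predict the step on any further core.

Only methoxy and nitro appear on the aromatic ring here. On these data alone, how an amine or a carboxylic acid at either place would read in this assay remains open.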